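A few compounds are considered here, and "the series" means these few. Any claim that something is new, unique, unknown or untested is made for them only; others in the source may bear on it.

For the measured compounds named here, in an ADME assay on H1-HeLa cells (Homo sapiens) for cytotoxicity, read by MTT assay, with a stated time of 3 days (on this read-out lower numbers stand for higher toxicity in this test and higher numbers for lower toxicity in this test), compound 1 (`CCOC(=O)c1sc2cc(Oc3ccnc(C(=O)NC)c3)ccc2c1C`) reads 50900 nM and stands at the upper end of the numbers so far, together with compound 3 (`CCCOC(=O)c1sc2cc(Oc3ccnc(C(=O)NC)c3)ccc2c1C`) at 37400 nM (a 1.4-fold lower number from compound 1 to compound 3 (0.13 log units; within the scatter)). Compound 2 (`CNC(=O)c1cc(Oc2ccc3c(C)c(C(=O)OC)sc3c2)ccn1`) reads 10800 nM and is the only one set apart (a 4.7-fold lower number from compound 1 to compound 2 (0.67 log units; beyond the scatter); also a 3.5-fold higher number from compound 2 to compound 3 (0.54 log units; beyond the scatter)).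

The next step leads to compound 4 (`CNC(=O)c1cc(Oc2ccc3c(C)c(C(=O)N(C)C)sc3c2)ccn1`): dimethylamino in place of ethoxy on a carbonyl carbon. Going by the values given here, no measured step makes this exchange. All three only alter the saturated chain on the oxygen next to the carbonyl group, so they bear on it indirectly and give no direction. The largest of them, the step to compound 2 (a 4.7-fold lower number from compound 1 to compound 2 (0.67 log units; beyond the scatter)), is modest and sets the size of move that the series has shown. With no direction available, no step beyond the scatter is expected, and the estimate stays close to compound 1 (50900 nM). The expected step is a 1.5-fold lower number from compound 1 to compound 4 (0.16 log units; within the scatter) (an estimate only). For compound 4 the estimated value is 35000 nM (expected range 12000 nM to 90000 nM).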

Compound 4, half-maximal cytotoxic concentration: 42500 nM
The estimate for compound 4 lay 1.2-fold (0.08 log units) below the measured number; the range from low to high includes it.
By their numbers in this assay, from the lowest: compound 2; then compounds 3, 4 and 1 (each within the scatter of the next).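

In this assay, for the compounds shown here, the first exchange on the carbonyl carbon itself, away from the saturated chain on the oxygen, stays within the scatter: a 1.2-fold lower number from compound 1 to compound 4 (0.08 log units; within the scatter). The same holds against the propoxy group, a 1.1-fold higher number from compound 3 to compound 4 (0.06 log units; within the scatter), whereas against the methoxy group the step lies beyond the scatter, a 3.9-fold higher number from compound 2 to compound 4 (0.59 log units; beyond the scatter), so compound 2 remains the only one set apart, now also from a compound with no oxygen at this place. No measured evidence is available to explain this result.

Open, as far as these compounds go, is whether the number stays in this range with a carboxylic acid, a primary amide or a morpholine amide on the same carbonyl carbon. Also open, from the compounds shown here alone, is whether monomethylamino, the shorter amine counterpart of methoxy, sets itself apart as compound 2 does, or whether a longer dialkylamino chain changes the number.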